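Shifting the Carboxylic Acid in Compound 1

This account rests on a few compounds, and the source may have more. Where it says the series, first, only, none or still open, it means among the compounds named here.

Compound 1 `CC(C)c1onc(-c2c(Cl)cccc2Cl)c1COc1ccc(N(C)C(=O)c2ccc(C(=O)O)cc2)c(C(F)(F)F)n1`: 208 nM
Compound 2 `CC(C)c1onc(-c2c(Cl)cccc2Cl)c1COc1ccc(NC(=O)c2ccc(C(=O)O)cc2)c(C(F)(F)F)n1`: 385 nM
Compound 3 `Cc1nc(OCc2c(-c3c(Cl)cccc3Cl)noc2C(C)C)ccc1N(C)C(=O)c1ccc(C(=O)O)cc1`: 1190 nM

In a functional assay on HEK293 cells for agonist activity at Bile acid receptor (Homo sapiens), read by a luciferase reporter (on this read-out lower numbers stand for an effect already at smaller amounts and higher numbers for an effect only at larger amounts of compound), compound 1 gives the lowest of the three numbers. Compound 2 stands nearest to it, with a 1.9-fold higher number from compound 1 to compound 2 (0.27 log units; within the scatter), so the two cannot be told apart. Compound 3 stands furthest away, with a 5.7-fold higher number from compound 1 to compound 3 (0.76 log units; beyond the scatter).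

Compound 4 `CC(C)c1onc(-c2c(Cl)cccc2Cl)c1COc1ccc(N(C)C(=O)c2cccc(C(=O)O)c2)c(C(F)(F)F)n1` keeps everything of compound 1 except that (3-carboxyphenyl in place of 4-carboxyphenyl on a carbonyl carbon). Neither measured step touches this part of the molecule: the step from compound 1 to compound 2 concerns the amide nitrogen, and the step from compound 1 to compound 3 concerns the trifluoromethyl group, so nothing measured here tells how the placement of the carboxylic acid matters. The expectation must therefore stay loose; a modest loss is expected, as a 2.4-fold higher number from compound 1 to compound 4 (0.38 log units; beyond the scatter), with a wide margin in both directions. Compound 4 is estimated at 500 nM, with a range from 150 nM to 2500 nM.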

Compound 4, half-maximal effective concentration: 537 nM
Compound 4: middle estimate off by 1.1-fold (0.03 log units), on the low side; the measured number falls inside the stated range.
By their numbers in this assay, from the lowest: compounds 1, 2 and 4 (each within the scatter of the next, the first and the last beyond it); then compound 3.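

Among these compounds, this is the first change measured at the aromatic ring on the carbonyl carbon, and it shows that the place of the carboxylic acid on that ring matters in this assay: 3-carboxyphenyl in place of 4-carboxyphenyl gives a 2.6-fold higher number from compound 1 to compound 4 (0.41 log units; beyond the scatter), a modest step. The two compounds hold the same atoms, joined differently, so a rearrangement alone is enough to move the number beyond the scatter. No measurement at hand explains why this rearrangement has that effect.

Still open, going by these compounds, is whether the carboxylic acid itself is needed, since a methyl ester or a primary amide in its place could keep the number or lose it. On these data alone, it is also open whether changes at the amide nitrogen or the trifluoromethyl group would act the same way with 3-carboxyphenyl present.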